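From Hydroxyphenyl to Methoxyphenyl: An Antiproliferative Estimate

The source may hold more compounds than are shown below. What is called first, only, known or untested is meant among the compounds shown, and "the series" means these compounds.

Measured compounds:
compound 1, `Cc1ccc(-c2cn(C/C=C3\OC(=O)C(OCc4ccccc4)=C3OCc3ccccc3)nn2)cc1`: > 100000 nM
compound 2, `O=C1O[C@H]([C@@H](O)Cn2cc(-c3cccc(O)c3)nn2)C(OCc2ccccc2)=C1OCc1ccccc1`: 42900 nM
compound 3, `CCCCCc1ccc(-c2cn(C/C=C3\OC(=O)C(OCc4ccccc4)=C3OCc3ccccc3)nn2)cc1`: > 100000 nM

In a functional assay on HCT-116 cells (Homo sapiens) for antiproliferative activity, read by MTT assay, with a stated time of 72 h (on this read-out lower numbers stand for stronger inhibition and higher numbers for weaker inhibition), compound 1 gives > 100000 nM, which is a limit of the assay rather than a number. Compound 3 likewise reaches only the limit > 100000 nM. Among the compounds with values here, compound 2 gives 42900 nM, the only number in the set, the other two values sitting at the limit of > 100000 nM in this assay, at which 2 of the 3 values shown sit. Within the data shown here, the single measured step, a step that the two limits leave unreadable from compound 1 to compound 3, is thus unreadable. Compound 4, `COc1ccccc1-c1cn(C[C@H](O)[C@H]2OC(=O)C(OCc3ccccc3)=C2OCc2ccccc2)nn1`, differs from compound 2 in this way: 2-methoxyphenyl in place of 3-hydroxyphenyl on an aromatic carbon. Among the measured compounds shown here, no measured step touches this change, so there is no basis for expecting a shift beyond the scatter. The step is estimated as a 1.0-fold higher number from compound 2 to compound 4 (0.02 log units; within the scatter). Compound 4 is therefore expected at 45000 nM, within a range from 12000 nM to 100000 nM.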

Compound 4, half-maximal inhibitory concentration: > 100000 nM
Compound 4: no number, only a limit; the forecaster's own chance of this, stated with the estimate: 35%; middle value at least 2.2-fold (0.34 log units) from the limit.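

In this assay, within the data shown here, putting 2-methoxyphenyl in place of 3-hydroxyphenyl on an aromatic carbon of the five-membered aromatic ring gives an at least 2.3-fold higher number from compound 2 to compound 4 (0.36 log units; beyond the scatter), the only readable step so far. Compound 4 gives > 100000 nM, which is a limit of the assay, so the step has no upper bound. Little of the series stays on scale: the limit of > 100000 nM in this assay, at which 3 of the 4 values shown sit.

The compounds shown do not separate the exchange of hydroxy for methoxy from the change in where the group sits. On these data alone, whether an amine or a carboxylic acid on that phenyl ring would give a number remains open.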